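The compounds below may be only part of what the source reports. "The series", "measured", "known", "first", "only" and "open" are said of these compounds alone.

Working notes on the series, read in an ADME assay on microsomes from liver (Homo sapiens) for metabolic stability, with a stated time of 60 min (on this read-out lower numbers stand for a less stable compound and higher numbers for a more stable compound), as the only measure so far. Compound 1 (`CCOP(=O)(OCC)OCCc1cn(-c2ccc(NC(=O)Nc3ccccc3C)cc2)nn1`) gives 53.7% and compound 2 (`CCCCc1cn(-c2ccc(NC(=O)Nc3ccccc3C)cc2)nn1`) gives 99% in this read-out, so compound 2 holds the higher of the two numbers. Compound 3 (`CCCCc1cn(-c2ccc(NC(=O)Nc3cc(OC4CCCC4)ccc3C)cc2)nn1`) is unmeasured and differs from compound 2 by cyclopentyloxy in place of hydrogen on an aromatic carbon, para to a methyl group.

Among the compounds with values here, only one measured step exists, a number 45.3 percentage points higher from compound 1 to compound 2 (beyond the scatter), which is large and beyond the scatter. It lies on a saturated chain carbon, not on an aromatic carbon, so it bears only indirectly: it shows that one change in this series can move the number by a wide margin. Within the data shown here, no measured step covers a substitution at this aromatic carbon. Compound 2 at 99% leaves almost no room upward, so any real step is expected to point down, probably by a moderate amount beyond the scatter (a number 27 percentage points lower from compound 2 to compound 3 (beyond the scatter) as the expected step). For compound 3 the estimate is 72% as the expected value, within an estimated range of 45% to 95% in this assay once it is measured.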

Compound 3, percent of the compound remaining: 92.5%
Estimate against measurement, compound 3: 20.5 percentage points below; the range from low to high includes it.
By their numbers in this assay, from the lowest: compound 1; then compounds 3 and 2 (each within the scatter of the next).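

In this assay, the aromatic carbon para to a methyl group takes cyclopentyloxy in place of hydrogen with a number 6.5 percentage points lower from compound 2 to compound 3 (within the scatter) and so with no readable change, even though the entering group brings a five-membered non-aromatic ring of carbon only. Within the data shown here, this is the only measured step on this six-membered aromatic ring, and it contrasts with the large step on the saturated chain carbon, a number 45.3 percentage points higher from compound 1 to compound 2 (beyond the scatter), showing that not every change moves the number by a wide margin. No measurement shown accounts for either step.

From the compounds shown here alone, whether this carbon gives a similar number with methoxy, an amine or a carboxylic acid in place of cyclopentyloxy remains open. Also open, going by these compounds, is how cyclopentyloxy at this carbon reads with the chain of compound 1, which gives 53.7% in this assay and leaves more room for a rise or a fall than a number near the top of the scale.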